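Methylsulfanyl in Place of Isopropoxy on the Anilide Ring

The source may hold more compounds than are shown below. What is called first, only, known or untested is meant among the compounds shown, and "the series" means these compounds.

Compound 1 `CC(C)Oc1cccc(NC(=O)CN2CCC(c3cccc[n+]3[O-])CC2)c1`: 48%
Compound 2 `N#Cc1cccc(C(=O)NCN2CCC(c3cccc[n+]3[O-])CC2)c1`: 69%
Compound 3 `COc1cccc(C(=O)NCN2CCC(c3cccc[n+]3[O-])CC2)c1C`: 51%

In a functional assay on HEK293 cells for agonist activity at D(4) dopamine receptor (Homo sapiens), read by FLIPR (on this read-out higher numbers stand for larger maximal responses and lower numbers for smaller maximal responses), compound 1 gives the lowest of the three numbers. Compound 3 stands within the scatter of it, so the two cannot be ordered; compound 2 stands beyond the scatter above it. Compound 4 `CSc1cccc(NC(=O)CN2CCC(c3cccc[n+]3[O-])CC2)c1` differs from compound 1 by one change: methylsulfanyl in place of isopropoxy on an aromatic carbon. Among the compounds with values here, no measured pair shows this change, so nothing in the data fixes its direction. The step from compound 1 to compound 4 in this assay is expected to stay within the scatter, with no clear direction, as a number 4 percentage points higher from compound 1 to compound 4 (within the scatter). Compound 4 is therefore estimated at 52%, in the range 35% to 70%.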

Compound 4, largest response reached (reported as efficacy), in percent of the reference or control that the assay uses: 56%
The estimate for compound 4 lay 4 percentage points below the measured number; measured number inside the range.
By their numbers in this assay, from the lowest: compounds 1, 3 and 4 (each within the scatter of the next); then compound 2.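

In this assay, within the data shown here, the swap of isopropoxy for methylsulfanyl gives a number 8 percentage points higher from compound 1 to compound 4 (within the scatter), the only measured pair for this change. At this place, meta to a large group, a substituent of 4 heavy atoms gives way to one of 2 with no step beyond the scatter, so the two groups cannot be ordered. Nothing available gives a reason for this result.

Going by these compounds, whether an amine, a carboxylic acid or a longer alkoxy chain at this carbon would move the maximal response beyond the scatter remains open. So does whether a hydrogen there would.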